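The source may report more compounds than this note shows. Statements on the series, on what has been measured and on what is new or still open speak of the compounds shown alone.

Measured in an ADME assay on HeLa cells (Homo sapiens) for inhibition, read by MTT assay, with a stated time of 48 h; a lower number here means a stronger inhibitor, a higher number a weaker inhibitor:
- Compound 1 `C=C(C)Cn1cc(/C=C/C(=O)CC(=O)C(=O)OCC)c2ccccc21`: "not determined" (no result reported)
- Compound 2 `CCOC(=O)C(=O)CC(=O)/C=C/c1cn(Cc2ccccc2)c2ccccc12`: > 40000 nM (a limit of the assay)
- Compound 3 `C=C(C)Cn1cc(/C=C/C(=O)CC(=O)C(=O)O)c2ccccc21`: 40000 nM

Among the measured compounds shown here, compound 3 holds the only actual number in this small set, 40000 nM. Compound 2 gives > 40000 nM, which is a limit and not a number. Compound 1 has no result, so it offers no comparison.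

The next compound to be tested in this assay is compound 4 `O=C(/C=C/c1cn(Cc2ccccc2)c2ccccc12)CC(=O)C(=O)O`. The change from compound 3 is phenyl in place of 1-methylethenyl on a saturated chain carbon bound to an aromatic nitrogen. Cut one bond further out, this reads 2-methylprop-2-en-1-yl to benzyl. For the measured compounds named here, no measured pair of compounds isolates this change, so its effect has not been seen directly. Compound 4 shares its benzyl group with compound 2, whose reading of > 40000 nM is a limit. That reading gives no sign of a stronger inhibitor, and compound 3 itself stands at 40000 nM.

A step no larger than the usual scatter is therefore expected, with no firm direction, and compound 4 may also be reported only as a limit. The expected change is no change at the digits printed from compound 3 to compound 4 (within the scatter). The estimate for compound 4 is 40000 nM, with an expected range from 18000 nM to 80000 nM.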

Compound 4, half-maximal inhibitory concentration: > 40000 nM
Compound 4 was reported as a limit (the forecaster's own chance of this, stated with the estimate: 45%); the middle value sits exactly at the limit.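

Phenyl in place of 1-methylethenyl on a saturated chain carbon bound to an aromatic nitrogen now has its first direct reading in this assay, and it gives no sign of a stronger inhibitor: a number no lower from compound 3 to compound 4 (the limit leaves the size open). Compound 4 gives > 40000 nM, which is a limit of the assay and not a number, so this step has a direction but no size. The step for hydrogen in place of ethyl on an oxygen next to a carbonyl group joins two limits and cannot be read, and the values shown for this position gather at one point: the limit of > 40000 nM in this assay, at which 2 of the 4 values shown sit.

The compounds shown leave open how far compound 4 lies past its limit, and whether any group at this place gives a reading clearly stronger than that of compound 3. An amine carried on the chain, or a longer chain in place of benzyl, would test whether this position can move the value in this assay at all.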